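Cytotoxicity notes on the aryl group of the series

The source may report more compounds than this note shows. Statements on the series, on what has been measured and on what is new or still open speak of the compounds shown alone.

compound 1 `Cc1cc(-c2cccs2)cc(C)c1Nc1ccnc(Nc2ccc(C#N)cc2)n1` gives 10000 nM
compound 2 `Cc1cc(-c2cc3ccccc3s2)cc(C)c1Nc1ccnc(Nc2ccc(C#N)cc2)n1` gives 138000 nM
compound 3 `Cc1cc(-c2ccnc(F)c2)cc(C)c1Nc1ccnc(Nc2ccc(C#N)cc2)n1` gives 6000 nM

All three values come from a toxicity assay on MT4 cells (Homo sapiens) for cytotoxicity, read by MTT assay, with a stated time of 5 days (on this read-out lower numbers stand for higher toxicity in this test and higher numbers for lower toxicity in this test), and the compounds differ in one group on the shared core. Compound 3 stands level with compound 1 within the scatter, with a 1.7-fold lower number from compound 1 to compound 3 (0.22 log units; within the scatter), and well under compound 2, with a 23-fold lower number from compound 2 to compound 3 (1.36 log units; beyond the scatter).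

The next change leads to compound 4 `Cc1cc(-c2cc(C)c(Nc3ccnc(Nc4ccc(C#N)cc4)n3)c(C)c2)cc(C)n1` and reads (2,6-dimethylpyridin-4-yl in place of 2-fluoropyridin-4-yl on an aromatic carbon). It places 2,6-dimethylpyridin-4-yl in place of 2-fluoropyridin-4-yl on an aromatic carbon, so both groups are a six-membered aromatic ring with 1 hetero atom.

Among the measured changes, the closest precedent is the exchange of thiophen-2-yl for 2-fluoropyridin-4-yl, a 1.7-fold lower number from compound 1 to compound 3 (0.22 log units; within the scatter), which stayed within the scatter. For the measured compounds named here, the large steps, a 14-fold higher number from compound 1 to compound 2 (1.14 log units; beyond the scatter) and the reverse exchange already noted, both involve the 1-benzothiophen-2-yl group of compound 2, which has no counterpart in compound 4, so they bear on this change only weakly. No step beyond the scatter is therefore expected in this assay, and no direction is firmly indicated. The expected change is a 1.3-fold higher number from compound 3 to compound 4 (0.12 log units; within the scatter). For compound 4 the estimated value is 8000 nM, with an expected range from 2500 nM to 30000 nM.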

Compound 4, half-maximal cytotoxic concentration: 2300 nM
The estimate for compound 4 lay 3.5-fold (0.54 log units) above the measured number; the measured number lies below the stated range.
By their numbers in this assay, from the lowest: compound 4; then compounds 3 and 1 (each within the scatter of the next); then compound 2.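

In this assay, one six-membered aromatic ring with 1 hetero atom replacing another at this position does not leave the number unchanged: 2,6-dimethylpyridin-4-yl in place of 2-fluoropyridin-4-yl gives a 2.6-fold lower number from compound 3 to compound 4 (0.42 log units; beyond the scatter), although the ring type and the hydrogen-bond donor and acceptor counts stay the same. Compound 4 now has the lowest number of the series, with a 4.3-fold lower number from compound 1 to compound 4 (0.64 log units; beyond the scatter) and a 60-fold lower number from compound 2 to compound 4 (1.78 log units; beyond the scatter), so the level shared within the scatter by compound 1 and compound 3 is not the lower end for this position. No measurement at hand accounts for this shift.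

The compounds shown do not separate the contribution of the methyl groups of 2,6-dimethylpyridin-4-yl from that of the fluorine they replace, so it remains open which of the two goes with the lower number. On these data alone, it also remains open whether the number would hold or move further with an amine or a carboxylic acid on the pyridin-4-yl group, or with a longer chain in place of the methyl groups.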